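Second Fluorine on the Benzyl Ring: Expected Cytotoxicity

The compounds below may be only part of what the source reports. "The series", "measured", "known", "first", "only" and "open" are said of these compounds alone.

Measured compounds:
compound 1, `CCOC(=O)/C(O)=C/C(=O)c1cn(Cc2cc(F)c(F)c(F)c2)c2cccc(OC)c12`: 33400 nM
compound 2, `CCOC(=O)/C(O)=C/C(=O)c1cn(Cc2cccc(F)c2)c2cccc(OC)c12`: 63200 nM

Both compounds share one core and were tested in an ADME assay on MT4 cells (Homo sapiens) for cytotoxicity, read by MTT assay; on this read-out lower numbers stand for higher toxicity in this test and higher numbers for lower toxicity in this test. Compound 2 holds the higher of the two numbers, but the gap between them is only a 1.9-fold higher number from compound 1 to compound 2 (0.28 log units; within the scatter), so the two compounds cannot be told apart on this read-out.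

Compound 3 `CCOC(=O)/C(O)=C/C(=O)c1cn(Cc2cccc(F)c2F)c2cccc(OC)c12` awaits measurement. It differs from compound 2 by fluoro in place of hydrogen on an aromatic carbon. Among the measured compounds shown here, the one measured step that bears on this change, a 1.9-fold higher number from compound 1 to compound 2 (0.28 log units; within the scatter), also altered only the fluorine pattern of that same ring and stayed within the scatter. No step beyond the scatter is therefore expected here. Compound 3 is expected to give about 50000 nM in this assay, most likely between 20000 nM and 125000 nM. The expected step is a 1.3-fold lower number from compound 2 to compound 3 (0.10 log units; within the scatter), an estimate resting on the two measured values alone.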

Compound 3, half-maximal cytotoxic concentration: 21100 nM
The estimate for compound 3 lay 2.4-fold (0.37 log units) above the measured number, and the stated range covers the measured number.
By their numbers in this assay, from the lowest: compounds 3, 1 and 2 (each within the scatter of the next, the first and the last beyond it).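

In this assay, among the compounds shown here, going from 3-fluorobenzyl to 2,3-difluorobenzyl gives a 3.0-fold lower number from compound 2 to compound 3 (0.48 log units; beyond the scatter) and so higher toxicity in this test, the first step in this small set to clear the scatter. The other new comparison, 2,3-difluorophenyl in place of 3,4,5-trifluorophenyl, gives a 1.6-fold lower number from compound 1 to compound 3 (0.20 log units; within the scatter) and does not separate the two compounds, so the count of fluorines alone does not set the number: compound 1 carries more fluorines than compound 3, yet the two cannot be told apart. No measurement available here explains why this added fluoro group shifts the number.

Still open, going by these compounds, is whether the shift belongs to fluoro itself or to any group at this ring carbon. A chloro group, a methoxy group or an amine at the same place would help to settle that.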